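Cyclopropyl Replacing Methyl at the Ether Chain End

A few compounds are considered here, and "the series" means these few. Any claim that something is new, unique, unknown or untested is made for them only; others in the source may bear on it.

Three measured compounds share one core that carries an amino group and an ether chain. Compound 3 `CCCOc1cccc2ccc(N)nc12` gives 1100 nM in an assay on cells with melanin-concentrating hormone receptor 1 (Homo sapiens) as the target, read by radioligand binding (on this read-out higher numbers stand for weaker inhibition and lower numbers for stronger inhibition), the highest of the three numbers, yet each gap to the others stays within the scatter. Compound 1 `COCC(C)Oc1cccc2ccc(N)nc12` gives 606 nM in this assay, and compound 2 `Nc1ccc2cccc(OCCC3CCCCC3)c2n1` gives 808 nM. Compound 4 `Nc1ccc2cccc(OCCC3CC3)c2n1` differs from compound 3 by cyclopropyl in place of methyl on a saturated chain carbon, two bonds along the chain from an oxygen on an aromatic ring. The step that bears most directly on this change is a 1.4-fold higher number from compound 2 to compound 3 (0.13 log units; within the scatter), the reverse of exchanging methyl for cyclohexyl at the same place; a 1.8-fold higher number from compound 1 to compound 3 (0.26 log units; within the scatter) was also small. A step no larger than the scatter is therefore expected, a 1.3-fold lower number from compound 3 to compound 4 (0.11 log units; within the scatter). Compound 4 is estimated at 850 nM, within a range of 400 nM to 1800 nM.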

Compound 4, half-maximal inhibitory concentration: 492 nM
Estimate against measurement, compound 4: 1.7-fold (0.24 log units) above; low and high end bracket the measured number.
By their numbers in this assay, from the lowest: compounds 4, 1, 2 and 3 (each within the scatter of the next, the first and the last beyond it).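

Cyclopropyl in place of methyl at this chain end gives a 2.2-fold lower number from compound 3 to compound 4 (0.35 log units; beyond the scatter), the first step in this series to pass the scatter. Cyclopropyl in place of cyclohexyl gives a 1.6-fold lower number from compound 2 to compound 4 (0.22 log units; within the scatter), and 2-cyclopropylethyl in place of 1-(methoxymethyl)ethyl gives a 1.2-fold lower number from compound 1 to compound 4 (0.09 log units; within the scatter), so neither of these two steps separates the groups compared. No measurement shown offers a reason for the step from methyl to cyclopropyl.

The compounds shown leave open how cyclobutyl or cyclopentyl would read at this place. They also leave open whether an amine at the chain end would keep the number this low.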